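Half-life notes on the step from compound 2 to compound 3

The compounds below may be only part of what the source reports. "The series", "measured", "known", "first", "only" and "open" are said of these compounds alone.

Two compounds of the series carry a number in an ADME assay on the whole organism (Rattus norvegicus, strain Sprague-Dawley) for metabolic stability, read by LC-MS, with a stated time of 24 h, at a dose of 1 mg/kg by the intravenous route; a higher number here means that the compound lasts longer, a lower number that the compound disappears faster. Compound 1 `CCC(=O)Nc1cc(Nc2ncc(Br)c(Nc3ccc4cc[nH]c4c3)n2)c(OC)cc1N1CCN(C)CC1` gives 2.88 h in this assay. Compound 2 `C=CC(=O)Nc1cc(Nc2ncc(Br)c(Nc3ccc4ccn(C)c4c3)n2)c(OC)cc1N1CCN(C)CC1` gives 3.47 h in this assay; on the two numbers shown compound 2 stands at the top, yet its gap to compound 1 lies within the scatter, so no order between the two is claimed. Among the compounds with values here, no pair of measured compounds differs in a single place, so the series holds no measured step to lean on.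

Compound 3 `C=CC(=O)Nc1cc(Nc2ncc(Br)c(Nc3ccc4c(c3)CCC4)n2)c(OC)cc1N1CCN(C)CC1` is not yet measured. It differs from compound 2 in one place: 2,3-dihydro-1H-inden-5-yl in place of 1-methyl-1H-indol-6-yl on a nitrogen on an aromatic ring. Within the data shown here, nothing among the measured compounds shows what this exchange does to the half-life, and the two numbers available sit within the scatter of each other. The expected step, a 1.2-fold lower number from compound 2 to compound 3 (0.06 log units; within the scatter), is therefore none beyond the scatter, with no direction preferred. For compound 3 the half-life in this assay is estimated at 3 h, with a range from 1.5 h to 6 h that covers the usual spread of repeated measurements and the unknown size of the exchange.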

Compound 3, half-life: 5.17 h
Estimate against measurement, compound 3: 1.7-fold (0.24 log units) below; measured number inside the range.
By their numbers in this assay, from the lowest: compounds 1, 2 and 3 (each within the scatter of the next).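

In this assay, within the data shown here, the series now has its only single-place step: 2,3-dihydro-1H-inden-5-yl in place of 1-methyl-1H-indol-6-yl on a nitrogen on an aromatic ring gives a 1.5-fold higher number from compound 2 to compound 3 (0.17 log units; within the scatter). At this position, then, the ring nitrogen and its hydrogen-bond acceptor can leave, and a five-membered non-aromatic ring of carbon only can replace the five-membered aromatic ring, without a difference in half-life beyond the scatter. No measurement at hand bears on what lies behind this number.

Among these compounds, the single step does not separate the loss of the ring nitrogen from the change of the five-membered ring, and compound 1 differs from both compound 2 and compound 3 in more than one place, so it adds no step to help with this. Also open, on these data alone, is whether any group at this position shifts the half-life beyond the scatter, for instance a phenyl ring carrying a carboxylic acid or an amine, or whether the position stays this tolerant across groups of a different kind.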